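Aryl Substituent Swap in a Sulfonamide Series

This account rests on a few compounds, and the source may have more. Where it says the series, first, only, none or still open, it means among the compounds named here.

Compound 1 `O=C(O)CCC/C=C\C[C@@H]1[C@H](O)CC[C@H]1NS(=O)(=O)c1ccc(Cl)cc1`: 2200 nM
Compound 2 `O=C(O)CCC/C=C\C[C@@H]1[C@H](O)CC[C@H]1NS(=O)(=O)c1ccc(F)cc1`: 6000 nM

In a functional assay (plasma) for inhibition, with Homo sapiens as the target (a lower number here means a stronger inhibitor, a higher number a weaker inhibitor), compound 2 gives the highest of the two numbers; its nearest neighbour is compound 1, with a 2.7-fold higher number from compound 1 to compound 2 (0.44 log units; beyond the scatter) separating them. Compound 3 `Cc1ccc(S(=O)(=O)N[C@@H]2CC[C@@H](O)[C@H]2C/C=C\CCCC(=O)O)cc1` differs from compound 2 by methyl in place of fluoro on an aromatic carbon. Within the data shown here, only that one step bears on the change: replacing chloro by fluoro raised the number, so exchanging fluoro for another group at the same carbon may well pull it back. Compound 3 is therefore expected to sit somewhat lower than compound 2, as a step of a 2.0-fold lower number from compound 2 to compound 3 (0.30 log units; within the scatter). The estimate for compound 3 is 3000 nM, spanning 1200 nM to 8000 nM.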

Compound 3, half-maximal inhibitory concentration: 5800 nM
The estimate for compound 3 lay 1.9-fold (0.29 log units) below the measured number, within the range that was stated.
By their numbers in this assay, from the lowest: compound 1; then compounds 3 and 2 (each within the scatter of the next).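

In this assay, methyl and fluoro at this carbon cannot be told apart (a 1.0-fold lower number from compound 2 to compound 3 (0.01 log units; within the scatter)), which shows that the earlier rise on leaving chloro is not peculiar to fluoro. Methyl in place of chloro gives a step of much the same size (a 2.6-fold higher number from compound 1 to compound 3 (0.42 log units; beyond the scatter)), so among these three compounds chloro alone stands at the lower number. Nothing measured here accounts for this. The compounds shown leave open whether bromo, methoxy or trifluoromethyl at the same carbon would follow chloro or stay with fluoro and methyl.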